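The source may report more compounds than this note shows. Statements on the series, on what has been measured and on what is new or still open speak of the compounds shown alone.

Compound 1 `COc1ccc(C#Cc2ccc(C(=O)N3CC[C@@H](O)C3)cc2)cc1` stands on the only number shown in the set; in a functional assay on TREX cells for negative allosteric modulation of metabotropic glutamate receptor 3 (Rattus norvegicus), read by calcium flux, with a stated time of 2.5 min (on this read-out higher numbers stand for weaker inhibition and lower numbers for stronger inhibition), compound 1 gives 10200 nM. Compound 2 `COc1ccc(C#Cc2ccc(C(=O)N3CCC[C@@H](CO)C3)cc2)cc1F` gives > 10000 nM in this assay, which is a limit of the assay rather than a number (the limit of > 10000 nM in this assay, at which 1 of the 2 values shown sits). Compound 3 `COc1ccc(C#Cc2ccc(C(=O)NC(C)CO)cc2)cc1` differs from compound 1 by (1-(hydroxymethyl)ethyl)amino in place of 3-hydroxypyrrolidin-1-yl on a carbonyl carbon. For the measured compounds named here, no measured step covers this change, so no step beyond the scatter is expected in either direction. Compound 3 is expected to give 10000 nM in this assay, within 4000 nM to 30000 nM. The step expected from compound 1 to compound 3 is a 1.0-fold lower number from compound 1 to compound 3 (0.01 log units; within the scatter).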

Compound 3, half-maximal inhibitory concentration: 7590 nM
Compound 3: the middle estimate sits 1.3-fold (0.12 log units) above what was measured, and the stated range covers the measured number.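

On the carbonyl carbon, the change to (1-(hydroxymethyl)ethyl)amino gives a 1.3-fold lower number from compound 1 to compound 3 (0.13 log units; within the scatter) in this assay, so within this one pair, the open chain reads the same as the 3-hydroxypyrrolidin-1-yl ring. At this position, the ring is thus not needed to hold the level of inhibition of compound 1. Nothing shown bears on why the two groups read alike.

Open, going by these compounds, is whether a group without the hydroxyl, such as dimethylamino, or a carboxylic acid on a longer chain, moves the number beyond the scatter. Also open, on these data alone, is whether any group on this carbonyl carbon gives much stronger inhibition.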